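Aminomethyl for acetyl at the edge of the shared core

The compounds below may be only part of what the source reports. "The series", "measured", "known", "first", "only" and "open" are said of these compounds alone.

Compound 1 `Nc1nc(NCc2ccccc2)nc(-c2ccccc2CO)n1`: 4.35
Compound 2 `Cc1ccccc1-c1nc(N)nc(NCc2ccccc2)n1`: "not active" (no number reported)
Compound 3 `CC(=O)c1ccccc1-c1nc(N)nc(NCc2ccccc2)n1`: "not active" (no number reported)

In a functional assay on cells for positive allosteric modulation of G-protein coupled receptor 68 (Homo sapiens), read by a luciferase reporter and cAMP accumulation, with a stated time of 30 min, at pH 6.8 and pH 8.3, in the presence of a further agent that is not named here (on this read-out lower numbers stand for lower potency and higher numbers for higher potency (the scale is a negative logarithm)), compound 3 stands without a single number, as one of two entries reported that way; only compound 1 has a measured value. Compound 4 `NCc1ccccc1-c1nc(N)nc(NCc2ccccc2)n1` differs from compound 3 by aminomethyl in place of acetyl on an aromatic carbon, on an aromatic carbon ortho to a large group. Among the compounds with values here, no step between measured compounds is known, so the size of this change cannot be read from the data; the aminomethyl group shares a hydrogen-bond donor and acceptor with the group carried by compound 1, which gave a low but measurable number. The value of compound 4 is therefore expected to be weak, estimated at 4.3 with a range from 3.8 to 4.8, and it may again be reported only as inactive.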

Compound 4, negative logarithm of the antagonist equilibrium constant: 3.86
Compound 4: middle estimate off by 0.44 log units, on the high side, and the stated range covers the measured number.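

Aminomethyl on this aromatic carbon ortho to a large group gives a measurable number in this assay, so compound 4 joins compound 1, whereas compound 3, with acetyl, has no number and the step between compound 3 and compound 4 cannot be read. Amino in place of hydroxy on the saturated chain carbon costs modest potency, a number 0.49 log units lower from compound 1 to compound 4 (beyond the scatter). No measured evidence accounts for this difference. Open, from the compounds shown here alone, is how a carboxylic acid or a longer chain ending in an amine would read at this place. Also open, going by these compounds, is whether a dimethylamino group on that chain carbon would give a number.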